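Thiazole acetic acids: swapping the aryl group at the ring nitrogen

The source may report more compounds than this note shows. Statements on the series, on what has been measured and on what is new or still open speak of the compounds shown alone.

Measured so far:
compound 1, `O=C(O)Cc1sc(C(c2ccccc2)c2ccc(Cl)cc2)nc1-c1ccc(F)cc1`, 79 nM;
compound 2, `NS(=O)(=O)c1ccc(-c2nc(C(c3ccc(F)cc3)c3ccc(F)cc3)sc2CC(=O)O)cc1`, > 100000 nM.

In an in vitro functional assay on HEK285-7 cells for antagonist activity at prostaglandin D2 receptor 2 (Homo sapiens), read by BRET and beta-arrestin recruitment (a lower number here means a stronger inhibitor, a higher number a weaker inhibitor), compound 1 gives 79 nM. Compound 2 gives only a limit in this assay, > 100000 nM, the reading (the limit of > 100000 nM in this assay, at which 1 of the 2 values shown sits). Going by the values given here, no step between measured compounds is available, so the two values show only that compound 1 is a clear inhibitor while compound 2 registers no inhibition up to the limit.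

Compound 3, `COc1cc(-c2nc(C(c3ccc(F)cc3)c3ccc(F)cc3)sc2CC(=O)O)ccn1`, has not yet been measured. It differs from compound 2 in one place: 2-methoxypyridin-4-yl in place of 4-sulfamoylphenyl on an aromatic carbon. This is 2-methoxypyridin-4-yl in place of 4-sulfamoylphenyl on an aromatic carbon. Since compound 2 stands at the limit, any gain for compound 3 must come from below that ceiling, and the estimate is a step of an at least 20-fold lower number from compound 2 to compound 3 (1.30 log units; beyond the scatter) toward stronger inhibition. Compound 3 is expected to give about 5000 nM in this assay, within a wide range from 300 nM to 60000 nM.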

Compound 3, half-maximal inhibitory concentration: 380 nM
For compound 3 the middle estimate is 13-fold (1.12 log units) above the measured one; the measured number falls inside the stated range.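

In this assay, the group on this aromatic carbon, next to the ring nitrogen, proves able on its own to carry a compound from no reading to a clear one: 2-methoxypyridin-4-yl in place of 4-sulfamoylphenyl gives an at least 260-fold lower number from compound 2 to compound 3 (2.42 log units; beyond the scatter), with the rest of the molecule unchanged. The size of that step is only a lower bound, as the value for compound 2 is a limit: the limit of > 100000 nM in this assay, at which 1 of the 3 values shown sits. The swap replaces a group that counts a hydrogen-bond donor with one that counts none, and a carbon-only ring with one holding a hetero atom, so these differences travel together.

Which of them matters stays open. A phenyl ring bearing methoxy, or the same pyridine ring bearing an amine instead of methoxy, would separate the ring from its substituent.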